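Trifluoromethyl for chloro on the aryl of compound 1

The source may report more compounds than this note shows. Statements on the series, on what has been measured and on what is new or still open speak of the compounds shown alone.

Measured so far:
compound 1 `CC(C)(C)c1cc(CNC(=O)Nc2cccc3[nH]ncc23)n(-c2cccc(Cl)c2)n1`: 0.6 nM
compound 2 `CC(=O)n1ncc2c(NC(=O)NCc3cc(C(C)(C)C)nn3-c3cccc(Cl)c3)cccc21`: 29.5 nM

Of the compounds shown here, two have been measured in an assay on CHO-K1 cells for antagonist activity at transient receptor potential cation channel subfamily V member 1 (Homo sapiens), read by FLIPR and calcium flux, with a stated time of 6 min; a lower number here means a stronger inhibitor, a higher number a weaker inhibitor. Compound 1 gives 0.6 nM and is the lower of the two numbers; compound 2 gives 29.5 nM. Going by the values given here, the one measured step, a 49-fold higher number from compound 1 to compound 2 (1.69 log units; beyond the scatter), concerns an acetyl in place of hydrogen on an aromatic nitrogen of the shared core and is large.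

Compound 3 `CC(C)(C)c1cc(CNC(=O)Nc2cccc3[nH]ncc23)n(-c2cccc(C(F)(F)F)c2)n1` keeps that core and the hydrogen on the aromatic nitrogen of compound 1 unchanged. Among the compounds with values here, its only difference from compound 1 is trifluoromethyl in place of chloro on an aromatic carbon. Within the data shown here, no measured step touches this aryl ring; the step from compound 1 to compound 2 sits on the other side of the molecule and says nothing about an exchange of chloro for trifluoromethyl. Among the measured compounds shown here, with no comparable step at hand, the expectation for compound 3 is a number close to that of compound 1, that is, a step of no change at the digits printed from compound 1 to compound 3 (within the scatter), which would lie within the scatter in either direction. Compound 3 is therefore estimated at 0.6 nM, with a range from 0.2 nM to 2 nM.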

Compound 3, inhibition constant: 0.3 nM
Estimate against measurement, compound 3: 2.0-fold (0.30 log units) above, within the range that was stated.
By their numbers in this assay, from the lowest: compounds 3 and 1 (each within the scatter of the next); then compound 2.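

In this assay, the exchange of 3-chlorophenyl for 3-(trifluoromethyl)phenyl gives a 2.0-fold lower number from compound 1 to compound 3 (0.30 log units; within the scatter), so this aryl position takes trifluoromethyl, with its four heavy atoms, in place of the single heavy atom of chloro without a difference that can be told from the scatter. Going by these compounds alone, the only earlier step lay elsewhere on the molecule: acetyl on the aromatic nitrogen gave a 49-fold higher number from compound 1 to compound 2 (1.69 log units; beyond the scatter), and the exchange on the aryl ring shows no step of that kind, although one exchange at one position does not make a pattern. Nothing measured on these compounds offers a reason why chloro and trifluoromethyl read alike here.

The compounds shown leave open whether this position also accepts a group of another kind, such as an amine, a carboxylic acid or a methoxy group, and whether the same holds elsewhere on the aryl ring. They also leave open whether trifluoromethyl would read the same as chloro with acetyl on the aromatic nitrogen, as the acetyl compound 2 carries chloro.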